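Swapping chloro for methoxy on a weakly active chalcone

The source may hold more compounds than are shown below. What is called first, only, known or untested is meant among the compounds shown, and "the series" means these compounds.

In an ADME assay on HEK293 cells (Homo sapiens) for antiproliferative activity, read by MTT assay, with a stated time of 24 h (on this read-out lower numbers stand for stronger inhibition and higher numbers for weaker inhibition), compound 1 `COc1cc(-c2cc(C(=O)/C=C/c3ccc(Cl)cc3)nc3cc(-c4ccccc4)nn23)cc(OC)c1OC` gives 53900 nM. Compound 2 `COc1ccc(-c2cc(C(=O)/C=C/c3ccc(Cl)cc3)nc3cc(-c4ccccc4)nn23)cc1OC` gives 39100 nM in this assay, and compound 3 `COc1ccc(C(=O)/C=C/c2cc(-c3ccc(OC)cc3)n3nc(-c4ccccc4)cc3n2)cc1` gives 36100 nM, so compound 1 sits alongside both, all three numbers within the scatter of one another. For the measured compounds named here, the only measured step, a 1.4-fold lower number from compound 1 to compound 2 (0.14 log units; within the scatter), removes a methoxy from the shared core and changes little. Compound 4 `COc1ccc(/C=C/C(=O)c2cc(-c3cc(OC)c(OC)c(OC)c3)n3nc(-c4ccccc4)cc3n2)cc1` differs from compound 1 by methoxy in place of chloro on an aromatic carbon. Going by the values given here, no measured step swaps chloro for methoxy; compound 3 carries a methoxyphenyl in place of that chlorophenyl but also differs elsewhere, so its value only shows that such compounds stay weak. The step from compound 1 to compound 4 is therefore expected to be small, a 1.2-fold lower number from compound 1 to compound 4 (0.08 log units; within the scatter). Compound 4 is estimated at 45000 nM, within 20000 nM to 100000 nM.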

Compound 4, half-maximal inhibitory concentration: 46600 nM
Beside the measured number, compound 4's estimate is 1.0-fold (0.02 log units) below it, and the stated range covers the measured number.
By their numbers in this assay, from the lowest: compounds 3, 2, 4 and 1 (each within the scatter of the next).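

For the compounds shown here, this is the first direct reading of methoxy in place of chloro at this position, para to a large group: in this assay the step is a 1.2-fold lower number from compound 1 to compound 4 (0.06 log units; within the scatter) and stays within the scatter. Chloro and methoxy therefore cannot be told apart here on the core of compound 1. Nothing measured here explains this result. As far as these compounds go, whether an amine or a carboxylic acid at this position would shift the number beyond the scatter remains open. So does whether this exchange would give the same result on another core.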